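Replacing the benzyl aryl ring with a cyclopentyl group

A few compounds are considered here, and "the series" means these few. Any claim that something is new, unique, unknown or untested is made for them only; others in the source may bear on it.

Three analogues sharing one core have been tested in a functional assay on the whole organism for antagonist activity, with Mus musculus as the target; on this read-out lower numbers stand for an effect already at smaller amounts and higher numbers for an effect only at larger amounts of compound. Compound 1 `COc1cc(N)c(Cl)cc1NC(=O)C1CCN(Cc2cccc(C)c2)CC1` gives 2.4 mg/kg. Compound 2 `COc1cc(N)c(Cl)cc1NC(=O)C1CCN(Cc2ccc(Cl)cc2)CC1` gives 1.2 mg/kg. Compound 3 `CCOc1ccc(CN2CCC(C(=O)Nc3cc(Cl)c(N)cc3OC)CC2)cc1` gives 6.3 mg/kg, the highest of the three numbers: it sits a 2.6-fold higher number from compound 1 to compound 3 (0.42 log units; beyond the scatter) and a 5.3-fold higher number from compound 2 to compound 3 (0.72 log units; beyond the scatter), while the remaining pair differ by a 2.0-fold lower number from compound 1 to compound 2 (0.30 log units; within the scatter).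

Compound 4 `COc1cc(N)c(Cl)cc1NC(=O)C1CCN(CC2CCCC2)CC1` differs from compound 3 by a single change: cyclopentyl in place of 4-ethoxyphenyl on a saturated chain carbon bound to an amine nitrogen in a ring. The measured steps that touch this position are those from compound 1 to compound 3 and from compound 2 to compound 3, both of which swapped one aromatic substituent for another and moved the number by a modest amount in this assay. None of them exchanged the aromatic ring itself for a non-aromatic one, so the direction of the present step is not anchored by any measured pair.

Given that compound 3 already holds the highest number, compound 4 is expected to land near it, with the step of a 1.6-fold lower number from compound 3 to compound 4 (0.20 log units; within the scatter) estimated as small. The estimate for compound 4 is 4 mg/kg, within a range from 1.2 mg/kg to 14 mg/kg.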

Compound 4, dose for half-maximal effect: > 10 mg/kg
Compound 4 gave a limit, no number; the forecaster's own chance of this, stated with the estimate: 10%; middle value at least 2.5-fold (0.39 log units) away from the limit.
By their numbers in this assay, from the lowest: compounds 2 and 1 (each within the scatter of the next); then compound 3. At a limit, above all of these: compound 4.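

Compound 4 is held at a limit of the assay, not a number: the limit of > 10 mg/kg in this assay, at which 1 of the 4 values shown sits.

This is the first change shown that removes the aromatic ring from this position, and with cyclopentyl on the saturated chain carbon bound to an amine nitrogen in a ring, this assay shows an at least 8.3-fold higher number from compound 2 to compound 4 (0.92 log units; beyond the scatter) and an at least 4.1-fold higher number from compound 1 to compound 4 (0.61 log units; beyond the scatter). Against the 4-ethoxyphenyl group, the reading is weaker: an at least 1.5-fold higher number from compound 3 to compound 4 (0.20 log units; that floor lies within the scatter) has a floor that does not separate compound 4 from compound 3.

As far as these compounds go, how far the true value of compound 4 lies past its limit remains open, and with it the full size of all three steps. Also open, from the compounds shown here alone, is whether a cyclohexyl group, a pyridine ring or a longer chain at this position would give numbers close to those of compound 1 and compound 2.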